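A few compounds are considered here, and "the series" means these few. Any claim that something is new, unique, unknown or untested is made for them only; others in the source may bear on it.

Compound 1 `Cc1ccc([C@@H](C)Oc2cc3oc(=O)n(CCC(=O)O)c3cc2Cl)nc1`: 22 nm/s
Compound 2 `O=C(O)CCn1c(=O)oc2cc(OCC3CCC3)c(Cl)cc21`: 12 nm/s

Both values come from a physicochemical assay for permeability, using PAMPA (on this read-out lower numbers stand for lower permeability and higher numbers for higher permeability), and compound 2 lies within the usual scatter of compound 1, so the two cannot be ranked. Compound 3 `C[C@@H](Oc1cc2oc(=O)n(CCC(=O)O)c2cc1Cl)c1cccnn1` differs from compound 2 in one place: a group of 8 heavy atoms (6 carbon, 2 nitrogen; one six-membered aromatic ring with 2 hetero atoms) in place of a group of 5 heavy atoms (5 carbon; one four-membered non-aromatic ring of carbon only), on an oxygen on an aromatic ring. Among the measured compounds shown here, no measured pair shows what such a swap does, so any forecast is loose. Compound 1, whose group on that oxygen also holds an aromatic ring, gives 22 nm/s, which points to no large loss. The estimated change is a 1.5-fold lower number from compound 2 to compound 3 (0.18 log units; within the scatter), no more than the scatter. For compound 3 the expected value is 8 nm/s, with an estimated range of 3 nm/s to 20 nm/s.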

Compound 3, apparent permeability: < 3 nm/s
Compound 3 was reported as a limit; the forecaster's own chance of this, stated with the estimate: 10%; middle value at least 2.6-fold (0.42 log units) away from the limit.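

In this assay compound 3 is reported as a limit and not as a number: the limit of < 3 nm/s in this assay, at which 1 of the 3 values shown sits.

Even so, the group on this oxygen can move the read-out beyond the scatter, with an at least 4.0-fold lower number from compound 2 to compound 3 (0.60 log units; beyond the scatter). An aromatic ring there does not settle the outcome, as pyridazin-3-yl in place of 5-methylpyridin-2-yl gives an at least 7.3-fold lower number from compound 1 to compound 3 (0.86 log units; beyond the scatter).

That swap changes both the ring nitrogens and the methyl, so the compounds shown cannot tell which of the two carries the step. A plain pyridin-2-yl group or a 5-methylpyridazin-3-yl group on the same carbon would separate them.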